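This account rests on a few compounds, and the source may have more. Where it says the series, first, only, none or still open, it means among the compounds named here.

Working notes on the series, step from compound 1 to compound 4.

The shared core carries a changing aryl group. In a functional assay on A549 cells (Homo sapiens) for inhibition, read by CCK-8 assay, with a stated time of 48 h (on this read-out higher numbers stand for weaker inhibition and lower numbers for stronger inhibition), compound 1 `COc1cc(-c2ccnc3cc(-c4ccc(C(C)(C)C)cc4)nn23)cc(OC)c1OC` gives only a limit, > 10000 nM, not a number (the limit of > 10000 nM in this assay, at which 1 of the 3 values shown sits). Compound 2 `COc1cc(-c2ccnc3cc(-c4ccc(C(C)=O)cc4)nn23)cc(OC)c1OC` gives 4100 nM in this assay, and compound 3 `COc1cc(-c2ccnc3cc(-c4c[nH]c5ccccc45)nn23)cc(OC)c1OC` gives 29 nM. Compound 1 thus stands at the weak end of the three, with the other two beyond the scatter from it.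

The change to compound 4 `COc1cc(-c2ccnc3cc(-c4ccc(F)cc4)nn23)cc(OC)c1OC` is fluoro in place of tert-butyl on an aromatic carbon. The step that bears most directly on it is an at least 2.4-fold lower number from compound 1 to compound 2 (0.38 log units; beyond the scatter), a swap at the same aromatic carbon that gave an at least modest improvement. The steps of an at least 340-fold lower number from compound 1 to compound 3 (2.53 log units; beyond the scatter) and a 140-fold lower number from compound 2 to compound 3 (2.15 log units; beyond the scatter) are large but replace the whole aryl with 1H-indol-3-yl, which is a different kind of change and offers no closer guide. Exchanging tert-butyl for fluoro at the same position is expected to behave like the move to acetyl rather than like the move to indolyl, so for compound 4 a modest gain, an at least 2.5-fold lower number from compound 1 to compound 4 (0.39 log units; beyond the scatter), is expected in this assay, with a real chance that only a limit is again reported. Compound 4 is estimated at 4000 nM, within 1000 nM to 15000 nM.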

Compound 4, half-maximal inhibitory concentration: 3800 nM
Beside the measured number, compound 4's estimate is 1.1-fold (0.02 log units) above it; measured number inside the range.
By their numbers in this assay, from the lowest: compound 3; then compounds 4 and 2 (each within the scatter of the next). At a limit, above all of these: compound 1.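

Fluoro in place of tert-butyl gives an at least 2.6-fold lower number from compound 1 to compound 4 (0.42 log units; beyond the scatter) in this assay, so a second group at this place on the phenyl ring, after acetyl, moves the read-out beyond the scatter from compound 1. Fluoro and acetyl are not separated here, with a 1.1-fold lower number from compound 2 to compound 4 (0.03 log units; within the scatter), while the exchange of the whole aryl group still dominates, with a 130-fold higher number from compound 3 to compound 4 (2.12 log units; beyond the scatter): among the compounds shown, changing the group on the phenyl ring from acetyl to fluoro does nothing measurable, and only the 1H-indol-3-yl group of compound 3 reaches the far lower level. The size of the first step remains a floor, since compound 1 has a limit and not a number: the limit of > 10000 nM in this assay, at which 1 of the 4 values shown sits.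

As far as these compounds go, what an amine, a hydroxyl or a carboxylic acid in place of fluoro would give at this same place remains open, and two groups that are not separated do not define a trend across the phenyl series. From the compounds shown here alone, it also remains open whether the level of compound 3 depends on the indole hydrogen on nitrogen, which a 1-methyl-1H-indol-3-yl group at the same carbon would address.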